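Working notes: kinetic solubility across a shared core

The compounds below may be only part of what the source reports. "The series", "measured", "known", "first", "only" and "open" are said of these compounds alone.

Measured so far in a physicochemical assay for solubility, in phosphate buffer, measured as kinetic solubility; a higher number here means a more soluble compound, a lower number a less soluble compound:
- compound 1 `CC(C)[C@H](C[C@H]1CCNC1=O)c1ccc(-c2ccc3cccc(F)c3c2)[nH]c1=O`: 26800 nM
- compound 2 `CC(C)C(c1ccc(-c2ccc3cccc(F)c3c2)[nH]c1=O)N1CCN/C1=N\C#N`: 25200 nM
- compound 3 `CC(C)[C@@H](C[C@H]1CCNC1=O)c1ccc(-c2ccc3cccc(F)c3c2)[nH]c1=O`: 32000 nM

All three numbers sit close together; compound 2 has the smallest of them, yet its gaps to compound 1 and to compound 3 both lie within the scatter of repeated measurements, so no order among the three can be claimed. Among the measured compounds shown here, the only measured step between single-point neighbours is a 1.2-fold higher number from compound 1 to compound 3 (0.08 log units; within the scatter), and it is explained by the fact that compounds 1 and 3 differ only in the configuration as drawn, which leaves the atom and bond pattern untouched.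

Compound 4 `CC(C)NC(=O)CC(c1ccc(-c2ccc3cccc(F)c3c2)[nH]c1=O)C(C)C` is not yet measured. Relative to compound 2 the change is a group of 7 heavy atoms (5 carbon, 1 nitrogen, 1 oxygen; no ring) in place of a group of 8 heavy atoms (4 carbon, 4 nitrogen; one five-membered non-aromatic ring with 2 hetero atoms), on a saturated chain carbon bound to an aromatic carbon and a saturated chain carbon. For the measured compounds named here, no measured step alters the heavy-atom pattern in this way, so the one known step gives no direct guide to the size or direction of the change in this assay; it only shows that the core tolerates small edits without leaving the scatter. With nothing pointing either way, a step of a 1.1-fold higher number from compound 2 to compound 4 (0.03 log units; within the scatter) is expected, that is, none beyond the scatter. Compound 4 is therefore estimated at 27000 nM, with a range of 12000 nM to 60000 nM.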

Compound 4, solubility: 18000 nM
For compound 4 the middle estimate is 1.5-fold (0.18 log units) above the measured one; the measured number falls inside the stated range.
By their numbers in this assay, from the lowest: compounds 4, 2, 1 and 3 (each within the scatter of the next).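

In this assay the exchange of the five-membered non-aromatic ring group for (isopropylcarbamoyl)methyl gives a 1.4-fold lower number from compound 2 to compound 4 (0.15 log units; within the scatter) and so leaves the number within the scatter. Unlike the earlier step, which touched only the configuration as drawn, this one replaces the whole group on a saturated chain carbon bound to an aromatic carbon and a saturated chain carbon, and a cyclic group and an open-chain group are not told apart here. Among the compounds shown here, nothing measured so far explains this step.

On these data alone, whether an amine, a carboxylic acid or a longer chain on this carbon would take the number beyond the scatter remains open. Also open, as far as these compounds go, is whether the configuration as drawn at this carbon matters with (isopropylcarbamoyl)methyl in place.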